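The compounds below may be only part of what the source reports. "The series", "measured", "known", "first", "only" and "open" are said of these compounds alone.

Of the compounds shown here, three have been tested so far in an ADME assay on HEK293 cells (Homo sapiens) for cytotoxicity, read by resazurin assay, with a stated time of 72 h (a higher number here means that more compound is tolerated, a lower number that less compound is tolerated), and none of them yields an exact number. Compound 1 `O=C(O)c1ccc(CCOc2c(F)ccc3nc(C(=O)NCc4cccc(OCC5CC5)c4)[nH]c(=O)c23)cc1` gives > 20000 nM as a limit of the assay and not a measured number. Compound 2 `O=C(O)c1ccc(COCc2cccc3nc(C(=O)NCc4ccccc4)[nH]c(=O)c23)cc1` gives > 20000 nM and this too is a limit. Compound 3 `CCc1ccc(CNC(=O)c2nc3cccc(COCc4ccc(C(=O)O)cc4)c3c(=O)[nH]2)cc1` gives > 20000 nM as a limit as well. Compound 3 therefore stands with the others, and the whole record reads as the limit of > 20000 nM in this assay, at which 3 of the 3 values shown sit, in a single line.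

Compound 4 `CCc1ccnc(CNC(=O)c2nc3cccc(COCc4ccc(C(=O)O)cc4)c3c(=O)[nH]2)c1` keeps the shared core of compound 3 and alters one group, as counted here: 4-ethylpyridin-2-yl in place of 4-ethylphenyl on a saturated chain carbon bound to an amide-type nitrogen with 4-ethylpyridin-2-yl in place of 4-ethylphenyl on a saturated chain carbon bound to an amide-type nitrogen.

Going by the values given here, the only measured step that changes one place is a step that the two limits leave unreadable from compound 2 to compound 3 and it offers no size to carry over. Among the compounds with values here, no measured pair tests this swap of a ring carbon for a ring nitrogen. The expectation therefore rests on the limit shared by all three compounds, and no change beyond the scatter is expected, with the estimated step being a number no higher from compound 3 to compound 4 (the limit leaves the size open) in this assay for now. For compound 4 the estimate is 20000 nM with an expected range from 10000 nM to 40000 nM and most likely the assay will again report only a limit.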

Compound 4, half-maximal cytotoxic concentration: > 20000 nM
Compound 4 ended at the assay's limit (the forecaster's own chance of this, stated with the estimate: 85%); the middle value sits exactly at the limit.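

In this assay, neither the step from compound 2 to compound 4 nor the step from compound 3 to compound 4 can be read, and all four compounds share one reading: the limit of > 20000 nM in this assay, at which 4 of the 4 values shown sit.

The compounds shown leave open at what concentration any of them would harm the cells, and whether 4-ethylpyridin-2-yl in place of 4-ethylphenyl changes that concentration at all.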